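Exchanging the Amide Substituent on the Way to Compound 4

The compounds below may be only part of what the source reports. "The series", "measured", "known", "first", "only" and "open" are said of these compounds alone.

This account concerns three measured compounds and one that still awaits measurement in a toxicity assay on HepG2 cells (Homo sapiens) for inhibition, read by CellTiter-Glo, with a stated time of 48 h; a lower number here means a stronger inhibitor, a higher number a weaker inhibitor. Compound 1 `CCOc1ccc2nc(C(F)(F)F)cc(OCC(=O)Nc3cc(C)cc(C)c3)c2c1` carries a trifluoromethyl group on the shared core, and in this assay compound 1 gives only a limit, > 100000 nM. For the measured compounds named here, compound 2 `COc1ccc2nc(C)cc(OCCNc3cc(C)cc(C)c3)c2c1` has an amine linker in place of an amide and is the only compound here with a number in this assay, compound 2 giving 31600 nM. Compound 3 `COc1ccc2nc(C)cc(OCC(=O)Nc3cc(C)ccc3OC)c2c1` likewise returns only a limit in this assay, compound 3 giving > 100000 nM. Going by the values given here, compound 3 thus stands at the limit of > 100000 nM in this assay, at which 2 of the 3 values shown sit, together with compound 1, while compound 2 alone returns a number, and no step between measured compounds is available to gauge any single change.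

Compound 4 `COc1ccc2nc(C)cc(OCC(=O)Nc3c(C)cncc3C)c2c1` differs from compound 3 in one place: 3,5-dimethylpyridin-4-yl in place of 2-methoxy-5-methylphenyl on an amide-type nitrogen. With compound 3 offering only a limit as the starting point, the step from compound 3 to compound 4 is expected to be small, a number no higher from compound 3 to compound 4 (the limit leaves the size open), with no direction beyond the usual scatter. Compound 4 is accordingly estimated to give 100000 nM in this assay, within a range from 30000 nM to 300000 nM, so that compound 4 may well again return only a limit.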

Compound 4, half-maximal inhibitory concentration: 12600 nM
The estimate for compound 4 lay 7.9-fold (0.90 log units) above the measured number; the whole stated range lies above it.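

In this assay, the group on this amide-type nitrogen proves able to shift the read-out: 3,5-dimethylpyridin-4-yl in place of 2-methoxy-5-methylphenyl gives an at least 7.9-fold lower number from compound 3 to compound 4 (0.89 log units; beyond the scatter). For the compounds shown here, the earlier compounds offered no single change that could be read, so this is the only evidence here that the group at this place bears on the number, and the step lies beyond the usual scatter. The true size of the step stays open, and the step is only a bound, because compound 3 gives a limit of the assay and not a number: the limit of > 100000 nM in this assay, at which 2 of the 4 values shown sit.

The exchange alters several things at once, replacing a carbon-only ring with a ring holding a nitrogen and removing the methoxy group, and the compounds shown cannot tell which of these alterations carries the step or why it occurs. A plain phenyl group or a pyridine ring without its methyl groups on this nitrogen would help to separate these alterations, and the compounds shown also leave open whether the step would hold on the core of compound 1 or with the amine linker of compound 2.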